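Sulfonyl aryl swap toward a nitrophenyl in a bromobenzyl series

This account rests on a few compounds, and the source may have more. Where it says the series, first, only, none or still open, it means among the compounds named here.

Three compounds sharing one core, differing only in the aryl group on the sulfonyl sulfur, have been measured in a functional assay on MIA PaCa-2 cells (Homo sapiens) for inhibition, read by MTT assay, with a stated time of 72 h; on this read-out lower numbers stand for stronger inhibition of growth and higher numbers for weaker inhibition of growth. Compound 1 `O=S(=O)(NCCCCCCNCc1ccc(Br)cc1)c1cc(Cl)cc(Cl)c1` gives 12000 nM. Compound 2 `O=S(=O)(NCCCCCCNCc1ccc(Br)cc1)c1c(Cl)cccc1Cl` gives 14700 nM, and a 1.2-fold higher number from compound 1 to compound 2 (0.09 log units; within the scatter). Compound 3 `O=S(=O)(NCCCCCCNCc1ccc(Br)cc1)c1ccc2ccsc2c1` gives 6000 nM, the lowest of the three numbers; a 2.0-fold lower number from compound 1 to compound 3 (0.30 log units; within the scatter), while a 2.5-fold lower number from compound 2 to compound 3 (0.39 log units; beyond the scatter).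

Compound 4 `O=[N+]([O-])c1ccccc1S(=O)(=O)NCCCCCCNCc1ccc(Br)cc1` is not yet measured. Its change relative to compound 3 is 2-nitrophenyl in place of 1-benzothiophen-6-yl on a sulfonyl sulfur. All three measured steps bear on it, since each also exchanges the aryl group on the sulfonyl sulfur, and they span only a narrow band of numbers: the two dichlorophenyl compounds sit within the scatter of each other, and the benzothiophenyl compound 3 is lower than them by a modest margin at most. A single phenyl ring carrying a nitro group resembles the dichlorophenyl compounds 1 and 2 more than the two-ring group of compound 3, so the expected step in this assay from compound 3 to compound 4 is a 2.0-fold higher number from compound 3 to compound 4 (0.30 log units; within the scatter), upward, toward the dichlorophenyl numbers. Compound 4 is therefore estimated at 12000 nM, with a range from 5000 nM to 30000 nM.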

Compound 4, concentration for 50% growth inhibition: 11700 nM
For compound 4 the middle estimate is 1.0-fold (0.01 log units) above the measured one, within the range that was stated.
By their numbers in this assay, from the lowest: compounds 3, 4, 1 and 2 (each within the scatter of the next, the first and the last beyond it).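

In this assay the 2-nitrophenyl group, which puts nitrogen and oxygen on the aryl group where compound 1 and compound 2 carry chlorine, reads alike with both dichlorophenyl compounds, showing a 1.0-fold lower number from compound 1 to compound 4 (0.01 log units; within the scatter) and a 1.3-fold lower number from compound 2 to compound 4 (0.10 log units; within the scatter). Within the data shown here, the 2-nitrophenyl group, with its one six-membered ring, also cannot be told apart from the two-ring 1-benzothiophen-6-yl group, showing a 2.0-fold higher number from compound 3 to compound 4 (0.29 log units; within the scatter), so compound 4 stands within the scatter of all three others, and the only step beyond it among the four remains a 2.5-fold lower number from compound 2 to compound 3 (0.39 log units; beyond the scatter). Nothing shown here accounts for why such different aryl groups on the sulfonyl sulfur give such closely matched numbers.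

From the compounds shown here alone, all four aryl groups leave the numbers in one narrow band, so it remains open whether any other group on the sulfonyl sulfur, such as a phenyl ring bearing an amine or a carboxylic acid, or a plain alkyl group in place of the aryl ring, would move the number well outside that band. Going by these compounds, it also remains open whether a longer chain in the shared core would change how much the aryl group matters.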